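Compound 3 at the limit, and a cyclopropyl swap

This account rests on a few compounds, and the source may have more. Where it says the series, first, only, none or still open, it means among the compounds named here.

Of the compounds shown here, three have been read in a toxicity assay on THP-1 cells (Homo sapiens) for cytotoxicity; on this read-out lower numbers stand for an effect already at smaller amounts and higher numbers for an effect only at larger amounts of compound. Compound 1 (`COc1ccccc1-c1ccnc2c(O)c(-c3nc(C)n[nH]3)ncc12`) gives only a limit, > 50100 nM in this read-out. Compound 2 (`O=C(NCc1ccc(Cl)cc1)c1ccc2cccnc2c1O`) gives a number, 6310 nM on the same scale. Compound 3 (`O=C(NCc1ccc(Cl)cc1)c1ncc2ccccc2c1O`) also gives only a limit, > 50100 nM again. Compound 3 therefore stands at the limit of > 50100 nM in this assay, at which 2 of the 3 values shown sit, and has no exact number.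

Compound 4 (`O=C(NCC1CC1)c1ncc2ccccc2c1O`) has cyclopropyl in place of 4-chlorophenyl on a saturated chain carbon bound to an amide-type nitrogen. Among the compounds with values here, no measured pair isolates this change. In this assay, no step beyond the scatter is expected in either direction, an expectation resting on the limit of compound 3 (> 50100 nM). The expected step is a number no higher from compound 3 to compound 4 (the limit leaves the size open) and remains an estimate. For compound 4, the estimated value is 50100 nM, with an expected range from 20000 nM to 100000 nM (a limit is also likely).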

Compound 4, half-maximal effective concentration in the THP-1 assay: > 50100 nM
Compound 4: no number, only a limit; the forecaster's own chance of this, stated with the estimate: 65%; the middle value sits exactly at the limit.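

In the THP-1 assay compound 3 gives > 50100 nM, which is only a limit. In the THP-1 assay compound 4 gives > 50100 nM, which is also only a limit. Within the data shown here, no step between these two compounds can be read. The compounds shown leave open whether cyclopropyl in place of 4-chlorophenyl shifts the half-maximal effective concentration at all. In a physicochemical assay for lipophilicity, at pH 7.4 (on this read-out higher numbers stand for higher lipophilicity and lower numbers for lower lipophilicity), compound 3 gives 7.6 and compound 4 gives 3.3.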